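This account rests on a few compounds, and the source may have more. Where it says the series, first, only, none or still open, it means among the compounds named here.

Three compounds share one core. Compound 1 `N#CC1=C(N)N(c2ccc(S(N)(=O)=O)cc2)C2=C(C(=O)CCC2)C1c1ccccc1` gives 40% in a functional assay on Ehrlich cells (Mus musculus) for antiproliferative activity, read by trypan blue exclusion, with a stated time of 2 h, tested at 100 ug/mL; a lower number here means a weaker effect, a higher number a stronger effect of the compound at the concentration tested; compound 2 `COc1ccc(C2C(C#N)=C(N)N(c3ccc(S(N)(=O)=O)cc3)C3=C2C(=O)CCC3)cc1` gives 100%; compound 3 `N#CC1=C(N)N(c2ccc(S(N)(=O)=O)cc2)C2=C(C(=O)CCC2)C1c1c(O)ccc2ccccc12` gives 15%, the lowest of the three. The steps of a number 25 percentage points lower from compound 1 to compound 3 (beyond the scatter) and a number 85 percentage points lower from compound 2 to compound 3 (beyond the scatter) both concern the same saturated ring carbon. Compound 4 `N#CC1=C(N)N(c2ccc(S(N)(=O)=O)cc2)C2=C(C(=O)CCC2)C1c1cccs1` differs from compound 3 by thiophen-2-yl in place of 2-hydroxynaphthalen-1-yl on a saturated ring carbon. Going by these compounds, both earlier steps ended at compound 3 as the 2-hydroxynaphthalen-1-yl group entered, and its departure for a thiophen-2-yl group is expected to raise the number in this assay, though how closely a thiophen-2-yl group follows phenyl or 4-methoxyphenyl is unknown. Compound 4 is estimated at 45% (range 15% to 80%), an expected step of a number 30 percentage points higher from compound 3 to compound 4 (beyond the scatter).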

Compound 4, a percentage reported as activity, at one concentration (the size of the read-out at that concentration, not a potency): 100%
Compound 4: the middle estimate sits 55 percentage points below what was measured, outside the stated range (above it).
By their numbers in this assay, from the lowest: compound 3; then compound 1; then compounds 2 and 4 (each within the scatter of the next).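

At this saturated ring carbon, thiophen-2-yl matches 4-methoxyphenyl in this assay (no change at the digits printed from compound 2 to compound 4 (within the scatter)), so a high reading here does not depend on the methoxy group or on a six-membered aromatic ring. The same group also separates clearly from phenyl (a number 60 percentage points higher from compound 1 to compound 4 (beyond the scatter)) and from 2-hydroxynaphthalen-1-yl (a number 85 percentage points higher from compound 3 to compound 4 (beyond the scatter)). Nothing available explains these differences.

Going by these compounds, whether a cyclohexyl or furan-2-yl group at this carbon would keep the high reading stays open. So does whether the hydroxy group or the second aromatic ring of 2-hydroxynaphthalen-1-yl goes with the low reading of compound 3.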